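The source may report more compounds than this note shows. Statements on the series, on what has been measured and on what is new or still open speak of the compounds shown alone.

Compound 1 `Fc1ccc2nc(-c3cnccn3)n(C3CC3)c2c1` and compound 2 `N#Cc1ccc2nc(-c3cncnc3C(F)F)n(C3CC3)c2c1` share a core and were both tested in an ADME assay on cells for inhibition of cytochrome P450 11B1, mitochondrial (Homo sapiens), read by HPLC, with a stated time of 60 min; on this read-out lower numbers stand for stronger inhibition and higher numbers for weaker inhibition. In this assay compound 1 gives > 10000 nM; that is a limit and not a number, namely (the limit of > 10000 nM in this assay, at which 1 of the 2 values shown sits). In this assay, for the measured compounds named here, compound 2 gives 2040 nM, which is the only actual number in hand, so compound 2 stands alone as the single measured value.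

Compound 3 `N#Cc1ccc2nc(-c3cncnc3C(F)(F)F)n(C3CC3)c2c1` has not yet been measured. It differs from compound 2 by fluoro in place of hydrogen on a saturated chain carbon bound to an aromatic carbon and two fluorine atoms. Going by the values given here, no measured pair shows a step of this kind, so the expectation rests on compound 2 alone. The step from compound 2 to compound 3 is expected to be small, a 1.4-fold lower number from compound 2 to compound 3 (0.13 log units; within the scatter), not clearly beyond the usual scatter in either direction. Compound 3 is therefore estimated at 1500 nM in this assay, within a range from 500 nM to 5000 nM.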

Compound 3, half-maximal inhibitory concentration: 4170 nM
Beside the measured number, compound 3's estimate is 2.8-fold (0.44 log units) below it; the range from low to high includes it.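

Replacing difluoromethyl with trifluoromethyl gives a 2.0-fold higher number from compound 2 to compound 3 (0.31 log units; beyond the scatter), so inhibition in this assay becomes modestly weaker. For the compounds shown here, this is the first readable step at this position, a saturated chain carbon bound to an aromatic carbon and two fluorine atoms, and it shows that exchanging one hydrogen for one fluoro there can move the number just beyond the usual scatter. Compound 1 offers no number for comparison, only a limit: the limit of > 10000 nM in this assay, at which 1 of the 3 values shown sits.

One step cannot show why the number rises, or whether the same change would have a similar effect on a different core. The compounds shown also leave open how a plain methyl group, a hydroxymethyl group or an amine at this position would compare with difluoromethyl and trifluoromethyl.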